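Cytotoxicity of two ethers and a bromo analogue

This account rests on a few compounds, and the source may have more. Where it says the series, first, only, none or still open, it means among the compounds named here.

Measured compounds:
compound 1 `CN1Cc2ccc(OCc3cccnc3)cc2[C@@H](O)C1`: > 50000 nM
compound 2 `CN1Cc2ccc(OCc3ccc(Oc4ccc(F)cc4)cc3)cc2[C@@H](O)C1`: 5600 nM

Of the compounds shown here, two sharing one core have been tested in an ADME assay on Vero cells (Chlorocebus sabaeus) for cytotoxicity, read by sulforhodamine B assay, with a stated time of 72 h; on this read-out higher numbers stand for weaker inhibition and lower numbers for stronger inhibition. Compound 1 gives only a limit there, > 50000 nM, so its reading is not a number. Among the measured compounds shown here, compound 2 is the only member of the pair with a number, 5600 nM in this assay; it therefore stands alone. The reading of compound 1 sits at the edge of the assay (the limit of > 50000 nM in this assay, at which 1 of the 2 values shown sits), so the gap between the two cannot be sized.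

Compound 3 `CN1Cc2ccc(OCc3ccc(Br)cc3)cc2[C@@H](O)C1` has not yet been measured. It differs from compound 2 by bromo in place of 4-fluorophenoxy on an aromatic carbon. For the measured compounds named here, no measured pair shows this exact change, so the direction of the step rests on the structures alone. A small single-atom group now sits where the larger aryl ether stood, and the piece expects a move toward weaker inhibition, an estimated step of a 3.6-fold higher number from compound 2 to compound 3 (0.55 log units; beyond the scatter), with a real chance that only a limit is returned. For compound 3 the estimate in this assay is 20000 nM, within a range from 6000 nM to 50000 nM.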

Compound 3, half-maximal inhibitory concentration: 37000 nM
The estimate for compound 3 lay 1.9-fold (0.27 log units) below the measured number, within the range that was stated.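

Bromo in place of 4-fluorophenoxy, on an aromatic carbon para to a large group, gives the only fully sized step in this assay, a 6.6-fold higher number from compound 2 to compound 3 (0.82 log units; beyond the scatter), so this change at this position moves the reading toward weaker inhibition by more than the scatter. The step with 4-bromophenyl in place of pyridin-3-yl on a saturated chain carbon bound to an oxygen on an aromatic ring reads as an at least 1.3-fold lower number from compound 1 to compound 3 (0.13 log units; that floor lies within the scatter), and its floor does not establish an order between the two compounds. Compound 1 gives only a limit in this assay, so that step has a floor and no full size: the limit of > 50000 nM in this assay, at which 1 of the 3 values shown sits.

The compounds shown leave open whether the step from 4-fluorophenoxy to bromo follows from losing the outer aromatic ring, from losing the ether oxygen, or from exchanging the fluorine and bromine atoms. Going by these compounds, a plain phenoxy, a benzyl, a methoxy or a chloro at the same carbon would separate these readings, and how far each would shift the number in this assay remains unknown.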